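The compounds below may be only part of what the source reports. "The series", "measured", "known", "first", "only" and "open" are said of these compounds alone.

Measured in a functional assay on OVCAR-3 cells (Homo sapiens) for inhibition, read by MTT assay, with a stated time of 24 h; on this read-out lower numbers stand for stronger inhibition and higher numbers for weaker inhibition:
- compound 1 `CC1(C)[C@H]2CC[C@]1(C)N(Cc1cn(-c3ccccc3Br)nn1)C(=O)C2`: 140 nM
- compound 2 `CC1(C)[C@H]2CC[C@]1(C)N(Cc1cn(-c3ccccc3)nn1)C(=O)C2`: 50 nM

Of these two, compound 2 at 50 nM has the lower number and so shows the stronger inhibition in this assay. The next compound to consider is compound 3 `CC1(C)[C@H]2CC[C@]1(C)N(Cc1cn(-c3ccc(Br)cc3)nn1)C(=O)C2`, still unmeasured. It differs from compound 2 by bromo in place of hydrogen on an aromatic carbon, para to a large group, which reads as phenyl to 4-bromophenyl: bromo in place of hydrogen on an aromatic carbon.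

Among the measured compounds shown here, only one measured step bears on this change: a 2.8-fold lower number from compound 1 to compound 2 (0.45 log units; beyond the scatter). That step is modest but beyond the scatter, and it removes a bromo from compound 1 that sits on a different carbon of the same ring. Read in reverse, it suggests that adding a bromo raises the number. The different place of the bromo leaves the size uncertain, and a step within the scatter cannot be ruled out. The expected step is a 2.0-fold higher number from compound 2 to compound 3 (0.30 log units; within the scatter), a modest one towards weaker inhibition. The estimate for compound 3 is 100 nM, with an expected range of 35 nM to 280 nM.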

Compound 3, half-maximal inhibitory concentration: 140 nM
Beside the measured number, compound 3's estimate is 1.4-fold (0.15 log units) below it; the measured number falls inside the stated range.
By their numbers in this assay, from the lowest: compound 2; then compounds 1 and 3 (each within the scatter of the next).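

In this assay, bromo in place of hydrogen on an aromatic carbon, para to a large group, gives a 2.8-fold higher number from compound 2 to compound 3 (0.45 log units; beyond the scatter), so this position now has a direct reading of its own rather than one borrowed from a bromo on a different carbon of the ring. Moving the bromo gives no change at the digits printed from compound 1 to compound 3 (within the scatter), so the read-out does not separate 4-bromophenyl from 2-bromophenyl on the aromatic nitrogen. Among these three compounds, both bromo placements go with a higher number than the unsubstituted phenyl of compound 2, with no compound going against that, although the pattern rests on a single halogen and only these two places on the ring.

Still open, on these data alone, is whether a group other than bromo at the same carbon, such as fluoro, methoxy, an amine or a carboxylic acid, would also raise the number, or would leave it close to that of compound 2. The reason for the bromo steps also stays open, as no measurement on hand bears on what lies behind them.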